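The source may report more compounds than this note shows. Statements on the series, on what has been measured and on what is new or still open speak of the compounds shown alone.

Three compounds have so far been measured in an assay on HEK293 cells for displacement of a labelled ligand from NPC1-like intracellular cholesterol transporter 1 (Homo sapiens); a lower number here means a stronger inhibitor, a higher number a weaker inhibitor:

Compound 1, `CC(C)(C)c1ccc(C(=O)N2CCC3(CC2)C(=O)N(CC(=O)NCCCCCNS(C)(=O)=O)CN3c2ccccc2)cc1`, gives 5500 nM.
Compound 2, `CCc1nn(CC)c(C2CCN(C(=O)CN3CN(c4ccccc4)C4(CCN(C(=O)c5ccc(C(C)(C)C)cc5)CC4)C3=O)CC2)c1CC`, gives 4600 nM.
Compound 3, `CC(C)(C)OC(=O)NC1CCN(C(=O)CN2CN(c3ccccc3)C3(CCN(C(=O)c4ccc(C(C)(C)C)cc4)CC3)C2=O)CC1`, gives 8300 nM.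

All three share one core and differ only at the far end of the same side chain. The number for compound 1 lies among those of compound 2 and compound 3, and its gaps to both are within the usual scatter of repeated measurements, so none of the three can be called stronger or weaker than another on these numbers.

Compound 4, `CC(C)(C)OC(=O)NCCCNC(=O)CN1CN(c2ccccc2)C2(CCN(C(=O)c3ccc(C(C)(C)C)cc3)CC2)C1=O`, has not yet been measured. Compared with compound 1 the change is (tert-butoxycarbonyl)amino in place of 2-(methanesulfonamido)ethyl on a saturated chain carbon, three bonds along the chain from an amide-type nitrogen. Among the compounds with values here, only one measured step bears on this: a 1.8-fold higher number from compound 2 to compound 3 (0.26 log units; within the scatter). That step brings in the same (tert-butoxycarbonyl)amino group, although what it replaces there, 1,3,4-triethyl-1H-pyrazol-5-yl on a saturated ring carbon, is not what leaves here. Across the three measured compounds, rather different groups at this end of the chain give numbers within the scatter of one another, so for compound 4 no step beyond the scatter is expected in this assay. The expected step is a 1.2-fold higher number from compound 1 to compound 4 (0.07 log units; within the scatter). Compound 4 is estimated at 6500 nM, with a range from 2500 nM to 17000 nM.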

Compound 4, half-maximal inhibitory concentration: 4500 nM
For compound 4 the middle estimate is 1.4-fold (0.16 log units) above the measured one, and the stated range covers the measured number.
By their numbers in this assay, from the lowest: compounds 4, 2, 1 and 3 (each within the scatter of the next).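

In this assay, the change at this place, on a saturated chain carbon, three bonds along the chain from an amide-type nitrogen, gives a 1.2-fold lower number from compound 1 to compound 4 (0.09 log units; within the scatter), so on an open chain, as well as on the saturated ring of the earlier pair, this end group leaves the number within the scatter. The two groups carry the same counts of hydrogen-bond donors and acceptors, yet 5-(methanesulfonamido)pentyl and 3-((tert-butoxycarbonyl)amino)propyl differ in both chain length and terminal group, and this one step shows that the two changes together leave the number within the scatter, without separating them. No measurement at hand explains this result.

The compounds shown leave open what each change does alone, which would take the methanesulfonamido group on the propyl chain or the (tert-butoxycarbonyl)amino group on the pentyl chain. They also leave open whether a free amine or a carboxylic acid at the chain end, or a much longer chain, would move the number beyond the scatter, in either direction.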